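Four anilino and alkylamino analogues on a shared core

The source may report more compounds than this note shows. Statements on the series, on what has been measured and on what is new or still open speak of the compounds shown alone.

Measured so far:
Compound 1, `CCCCCCCCNc1nc(SCc2ccc(C(F)(F)F)cc2)nc2ccccc12`: 12600 nM
Compound 2, `Cc1ccccc1Nc1nc(SCc2ccc(C(F)(F)F)cc2)nc2ccccc12`: 24400 nM
Compound 3, `O=[N+]([O-])c1cccc(Nc2nc(SCc3ccc(C(F)(F)F)cc3)nc3ccccc23)c1`: > 50000 nM, which is a limit of the assay and not a number

Compound 3 sits at the limit of a functional assay on MGC-803 cells (Homo sapiens) for cytotoxicity, read by MTT assay, with a stated time of 72 h (on this read-out lower numbers stand for stronger inhibition and higher numbers for weaker inhibition), so only a bound and no number is known for it (the limit of > 50000 nM in this assay, at which 1 of the 3 values shown sits). Of the three, it is the weakest, since its steps to both others are beyond the scatter: an at least 3.9-fold higher number from compound 1 to compound 3 (0.59 log units; beyond the scatter) and an at least 2.0-fold higher number from compound 2 to compound 3 (0.31 log units; beyond the scatter). The step to compound 4, `COc1ccc(Nc2nc(SCc3ccc(C(F)(F)F)cc3)nc3ccccc23)cc1`, is 4-methoxyphenyl in place of 3-nitrophenyl on a nitrogen on an aromatic ring. Within the data shown here, only one measured step bears directly on this position among aryl groups, an at least 2.0-fold higher number from compound 2 to compound 3 (0.31 log units; beyond the scatter), and it shows a modest gain when 3-nitrophenyl gives way to another aryl group; the step of a 1.9-fold higher number from compound 1 to compound 2 (0.29 log units; within the scatter) lies within the scatter. On that basis a modest step downward is expected, an at least 2.0-fold lower number from compound 3 to compound 4 (0.30 log units; that floor lies within the scatter), placing compound 4 between compound 2 and the limit. Compound 4 is therefore estimated at 25000 nM, with a range from 8000 nM to 60000 nM.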

Compound 4, half-maximal inhibitory concentration: 13800 nM
Estimate against measurement, compound 4: 1.8-fold (0.26 log units) above, within the range that was stated.
By their numbers in this assay, from the lowest: compounds 1, 4 and 2 (each within the scatter of the next). At a limit, above all of these: compound 3.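

The change from 3-nitrophenyl to 4-methoxyphenyl shows that the poor result for compound 3 does not extend to every aryl group on this nitrogen: an at least 3.6-fold lower number from compound 3 to compound 4 (0.55 log units; beyond the scatter) in this assay. The 4-methoxyphenyl group stays within the scatter of both other groups, with a 1.8-fold lower number from compound 2 to compound 4 (0.25 log units; within the scatter) and a 1.1-fold higher number from compound 1 to compound 4 (0.04 log units; within the scatter), so among the four only 3-nitrophenyl stands apart. Compound 3 remains a limit of the assay and not a number: the limit of > 50000 nM in this assay, at which 1 of the 4 values shown sits.

The compounds shown leave open whether the loss goes with the nitro group itself or with where it sits on the ring, as this step changes both at once. They also leave open how an unsubstituted phenyl, or a phenyl bearing an amine or a carboxylic acid, would read in this assay.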